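From acetyl to neopentylcarbonyl: estimating one further step

The source may report more compounds than this note shows. Statements on the series, on what has been measured and on what is new or still open speak of the compounds shown alone.

Of the compounds shown here, two that share a core have been measured so far in a physicochemical assay for solubility; on this read-out higher numbers stand for higher solubility and lower numbers for lower solubility. Compound 1 `CN(C)CC(=O)N1CCC(NS(=O)(=O)c2cc(S(=O)(=O)c3ccccc3)ccc2C(F)(F)F)CC1` gives 100000 nM. Compound 2 `CC(=O)N1CCC[C@H]1C(=O)N1CCC(NS(=O)(=O)c2cc(S(=O)(=O)c3ccccc3)ccc2C(F)(F)F)CC1` gives 12500 nM, the lower of the two numbers.

The next compound, compound 3 `CC(C)(C)CC(=O)N1CCC[C@H]1C(=O)N1CCC(NS(=O)(=O)c2cc(S(=O)(=O)c3ccccc3)ccc2C(F)(F)F)CC1`, differs from compound 2 in one place, with tert-butyl in place of hydrogen on a saturated chain carbon bound to a carbonyl carbon. Read one bond further out, acetyl becomes neopentylcarbonyl.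

Among the measured compounds shown here, only one measured step bears on this change: an 8.0-fold lower number from compound 1 to compound 2 (0.90 log units; beyond the scatter). There, 1-acetylpyrrolidin-2-yl took the place of (dimethylamino)methyl on a carbonyl carbon. That step was modest in size and involved a different swap, so it offers only loose guidance. With no closer comparison available, the expectation follows an 8.0-fold lower number from compound 1 to compound 2 (0.90 log units; beyond the scatter) in direction, at a somewhat smaller size.

The expected change is a 3.1-fold lower number from compound 2 to compound 3 (0.49 log units; beyond the scatter). In this assay, compound 3 is estimated at 4000 nM, with an expected range from 1000 nM to 12500 nM.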

Compound 3, solubility: 25000 nM
Beside the measured number, compound 3's estimate is 6.3-fold (0.80 log units) below it, and the stated range ends below it.
By their numbers in this assay, from the lowest: compounds 2 and 3 (each within the scatter of the next); then compound 1.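

In this assay, placing tert-butyl in place of hydrogen on a saturated chain carbon bound to a carbonyl carbon gives a 2.0-fold higher number from compound 2 to compound 3 (0.30 log units; within the scatter), so a group of 4 heavy atoms with no ring enters at this place without a difference that stands out from the usual spread of repeated measurements. The other new comparison, 1-(neopentylcarbonyl)pyrrolidin-2-yl in place of (dimethylamino)methyl on a carbonyl carbon, gives a 4.0-fold lower number from compound 1 to compound 3 (0.60 log units; beyond the scatter), so this swap stays beyond the scatter with neopentylcarbonyl as it did with acetyl in the earlier step. No measurement is available here that would account for either result.

A single group at this place cannot show how far this lack of a clear difference extends, and a carboxylic acid or a longer chain in place of tert-butyl could give a quite different number. As far as these compounds go, it also remains open whether the gap to the (dimethylamino)methyl compound would persist with such groups on the pyrrolidin-2-yl side chain.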